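Moving the Methyl Around the Aryl Ring of Compound 3

The compounds below may be only part of what the source reports. "The series", "measured", "known", "first", "only" and "open" are said of these compounds alone.

Three measured compounds share one core and differ only in the aryl group attached to it. Compound 1 `CC(C)(C)Cc1c(-c2ccc(Cl)c(Cl)c2)sc(N)c1C(=O)c1ccc(Cl)cc1` carries a 3,4-dichlorophenyl group, compound 2 `COc1cccc(-c2sc(N)c(C(=O)c3ccc(Cl)cc3)c2CC(C)(C)C)c1` a 3-methoxyphenyl group, and compound 3 `Cc1ccc(-c2sc(N)c(C(=O)c3ccc(Cl)cc3)c2CC(C)(C)C)cc1` a 4-methylphenyl group. In an assay on CHO cells for displacement of a labelled ligand from adenosine receptor A3 (Homo sapiens), read by scintillation counting, tested at 10 uM (on this read-out higher numbers stand for more inhibition at the one concentration tested (going by the name of the read-out) and lower numbers for less inhibition), compound 1 gives 1%, compound 2 gives 1%, and compound 3 gives 1%. The three steps between them, no change at the digits printed from compound 1 to compound 2 (within the scatter), no change at the digits printed from compound 1 to compound 3 (within the scatter) and no change at the digits printed from compound 2 to compound 3 (within the scatter), all lie within the scatter, so compound 3 stands level with both companions, with essentially no inhibition at the single concentration tested.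

Compound 4 `Cc1ccccc1-c1sc(N)c(C(=O)c2ccc(Cl)cc2)c1CC(C)(C)C` differs from compound 3 in one way: 2-methylphenyl in place of 4-methylphenyl on an aromatic carbon. For the measured compounds named here, no measured step moves a methyl group around a ring in this manner, but every measured step exchanges one aryl group for another on the same aromatic carbon, and none of them shifted the read-out. The same outcome is therefore expected here: a step of a number 1 percentage points higher from compound 3 to compound 4 (within the scatter), nothing beyond the scatter. Compound 4 is estimated at 2%, with a range from -8% to 12%.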

Compound 4, a percentage reported as inhibition, at one concentration (the size of the read-out at that concentration, not a potency): 1%
For compound 4 the middle estimate is 1 percentage points above the measured one; measured number inside the range.
By their numbers in this assay, from the lowest: compounds 1, 2, 3 and 4 (each within the scatter of the next).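

In this assay, for the compounds shown here, moving the methyl so that 2-methylphenyl replaces 4-methylphenyl gives no change at the digits printed from compound 3 to compound 4 (within the scatter), and unlike the earlier steps, this one keeps the same atoms and only joins them differently. Set against the other aryl groups, the new compound shows no change at the digits printed from compound 2 to compound 4 (within the scatter) and no change at the digits printed from compound 1 to compound 4 (within the scatter), so on this aromatic carbon next to the ring sulfur, all four aryl groups shown read alike, and no compound goes against that. Nothing available offers a reason for this flat result.

From the compounds shown here alone, what a carboxylic acid or an amine on this aryl ring would do remains open, as does any change to the neopentyl, amino or (4-chlorophenyl)carbonyl groups. With all four compounds reading alike, the data cannot say whether the aryl group at this position matters to inhibition on a core that shows clear inhibition.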